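This account rests on a few compounds, and the source may have more. Where it says the series, first, only, none or still open, it means among the compounds named here.

Measured compounds:
compound 1 `CC(C)NC(=O)NCCS(=O)(=O)NC(=O)c1ccc(Nc2nc(NC3(c4ccc(Cl)cc4)CC3)nc(OCC(F)(F)F)n2)cc1` — in an ADME assay on microsomes from liver (Homo sapiens) for metabolic stability, with a stated time of 10 min (a higher number here means that more of the compound is left, a lower number that less of the compound is left), compound 1 gives 100%
compound 2 `O=C(NS(=O)(=O)C1CC1)c1ccc(Nc2nc(NC3(c4ccc(Cl)cc4)CC3)nc(OCC(F)(F)F)n2)cc1` — in this assay compound 2 gives 100%

Compound 2 stands level with compound 1 in this assay; the step from compound 1 to compound 2 reads no change at the digits printed from compound 1 to compound 2 (within the scatter), so swapping the 2-((isopropylcarbamoyl)amino)ethyl for cyclopropyl on the sulfonyl sulfur left the read-out where it was, and neither compound can be called the more stable of the two.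

Compound 3 `COC(=O)NCCS(=O)(=O)NC(=O)c1ccc(Nc2nc(NC3(c4ccc(Cl)cc4)CC3)nc(OCC(F)(F)F)n2)cc1` has not yet been measured in this assay. The change from compound 2 to compound 3 is 2-((methoxycarbonyl)amino)ethyl in place of cyclopropyl on a sulfonyl sulfur. Among the compounds with values here, the only measured step that bears on it is the one from compound 1 to compound 2, which was within the scatter although it exchanged a chain of comparable length at the same sulfonyl sulfur for cyclopropyl. Going back from cyclopropyl to a 2-((methoxycarbonyl)amino)ethyl chain is therefore expected to give no step beyond the scatter in this assay. The expected step from compound 2 to compound 3 is a number 5 percentage points lower from compound 2 to compound 3 (within the scatter). Compound 3 is estimated to give 95% in this assay, with a range from 80% to 100%.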

Compound 3, percent of the compound remaining: 90%
Beside the measured number, compound 3's estimate is 5 percentage points above it; measured number inside the range.
By their numbers in this assay, from the lowest: compounds 3, 1 and 2 (each within the scatter of the next).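

In this assay, the change to 2-((methoxycarbonyl)amino)ethyl in place of cyclopropyl on a sulfonyl sulfur gives a number 10 percentage points lower from compound 2 to compound 3 (within the scatter), so this second open chain, like the first, cannot be told apart from the small ring at this place. The series now also holds a comparison at the far end of the chain, where the ethyl link stays and methoxy replaces isopropylamino on a carbonyl carbon; this gives a number 10 percentage points lower from compound 1 to compound 3 (within the scatter), so that exchange also leaves no step beyond the scatter. Among the three compounds, every step in this read-out lies within the scatter, and no measurement shown explains the result or bears on what lies behind it.

Open is whether any group on the sulfonyl sulfur would give a step beyond the scatter in this assay, for instance a chain ending in a primary amine or a carboxylic acid, or a longer chain than the two shown. Also open, as far as these compounds go, is whether the same insensitivity would hold if the shared core were changed, as all three compounds carry it unchanged.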